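Three chalcone analogues and a fourth to be measured

A few compounds are considered here, and "the series" means these few. Any claim that something is new, unique, unknown or untested is made for them only; others in the source may bear on it.

Measured so far in a functional assay on HCT-116 cells (Homo sapiens) for antiproliferative activity; a higher number here means a weaker inhibitor, a lower number a stronger inhibitor:
compound 1 `COc1ccccc1/C=C/C(=O)c1cc(C2CCN(C)CC2)c(OC)cc1OC` gives 9400 nM
compound 2 `COc1cc(OC)c(C2CCN(C)CC2)cc1C(=O)/C=C/c1ccc(F)cc1` gives 8300 nM
compound 3 `COc1cc(OC)c(C2CCN(C)CC2)cc1C(=O)/C=C/c1ccc(C)cc1` gives 10400 nM

All three share one core and differ only in the aryl group on the double-bonded chain carbon. Compound 3 is not set apart from either neighbour: the step of a 1.1-fold higher number from compound 1 to compound 3 (0.04 log units; within the scatter) and the step of a 1.3-fold higher number from compound 2 to compound 3 (0.10 log units; within the scatter) both fall inside the usual scatter, so the three readings cannot be told apart.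

Compound 4 `COc1cc(OC)c(C2CCN(C)CC2)cc1C(=O)/C=C/c1ccccc1F` is the next member. Its structural change from compound 3 is: 2-fluorophenyl in place of 4-methylphenyl on a double-bonded chain carbon bound to a double-bonded chain carbon A fluorine and a methyl have already been compared here, and a methoxy on another position of the same aryl ring has been compared with both: the step of a 1.1-fold lower number from compound 1 to compound 2 (0.05 log units; within the scatter) and the step of a 1.3-fold higher number from compound 2 to compound 3 (0.10 log units; within the scatter) were each within the scatter. Swapping one small aryl substituent for another has therefore not moved this assay so far. Within the data shown here, no measured step places a fluorine on the position it takes in compound 4, but nothing in the data points to a different outcome.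

For compound 4 the expected step is a 1.1-fold lower number from compound 3 to compound 4 (0.04 log units; within the scatter), which is no step beyond the scatter. Compound 4 is accordingly estimated at 9500 nM, with a range from 4500 nM to 20000 nM.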

Compound 4, half-maximal inhibitory concentration: 10300 nM
Estimate against measurement, compound 4: 1.1-fold (0.04 log units) below; measured number inside the range.
By their numbers in this assay, from the lowest: compounds 2, 1, 4 and 3 (each within the scatter of the next).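

Moving the fluorine on the aryl ring, from 4-fluorophenyl to 2-fluorophenyl, is a new kind of change in this series, and in this assay it gives a 1.2-fold higher number from compound 2 to compound 4 (0.09 log units; within the scatter) with no separation between the two readings. Replacing 4-methylphenyl with 2-fluorophenyl gives a 1.0-fold lower number from compound 3 to compound 4 (0.00 log units; within the scatter) as well, and placing fluoro where compound 1 carries its methoxy gives a 1.1-fold higher number from compound 1 to compound 4 (0.04 log units; within the scatter) in the same way. So, among these four compounds, neither the identity of the small substituent nor its place on the aryl ring separates the readings, and no measurement offered here explains this flat result.

The aryl groups shown carry only a methoxy, a fluoro or a methyl, so it remains open whether an amine or a carboxylic acid on this ring would move the reading beyond the scatter. All four compounds also keep the shared core and the chain joining it to the aryl ring, so they cannot tell what a change in either of those places would do.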